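This account rests on a few compounds, and the source may have more. Where it says the series, first, only, none or still open, it means among the compounds named here.

Working notes on the series. Of the compounds shown here, three share one core and have been tested in an ADME assay on MT4 cells (Homo sapiens) for cytotoxicity, read by MTT assay; a lower number here means that less compound is tolerated, a higher number that more compound is tolerated. Compound 1 `COc1cccc2c1c(C(=O)/C=C(\O)C(=O)O)cn2Cc1ccc(F)c(F)c1` gives 71000 nM. Compound 3 `COc1cccc2c1c(C(=O)/C=C(\O)C(=O)O)cn2Cc1cc(F)cc(F)c1` gives 29500 nM. Compound 2 `CCOC(=O)/C(O)=C/C(=O)c1cn(Cc2ccc(F)c(F)c2F)c2cccc(OC)c12` gives 42700 nM; its number is the second highest of the three, with compound 3 nearest and compound 1 furthest, both within the scatter of compound 2, so no order among them is claimed. Among the measured compounds shown here, the only step with a single change is a 2.4-fold lower number from compound 1 to compound 3 (0.38 log units; beyond the scatter), which is modest and concerns a change of fluorine pattern on the phenyl at the same place.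

Compound 4 `CCOC(=O)/C(O)=C/C(=O)c1cn(Cc2c(F)cccc2F)c2cccc(OC)c12` is not yet measured. It differs from compound 2 by 2,6-difluorophenyl in place of 2,3,4-trifluorophenyl on a saturated chain carbon bound to an aromatic nitrogen. For the measured compounds named here, the only comparable precedent is a 2.4-fold lower number from compound 1 to compound 3 (0.38 log units; beyond the scatter), a fluorine rearrangement of modest size; the present change also removes one fluorine, but no measured pair addresses that. The step in this assay is therefore expected to be small, a 1.1-fold lower number from compound 2 to compound 4 (0.03 log units; within the scatter), likely within the scatter. Compound 4 is estimated at 40000 nM, with a range from 18000 nM to 90000 nM.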

Compound 4, half-maximal cytotoxic concentration: 63400 nM
Compound 4: the middle estimate sits 1.6-fold (0.20 log units) below what was measured; low and high end bracket the measured number.
By their numbers in this assay, from the lowest: compounds 3, 2, 4 and 1 (each within the scatter of the next, the first and the last beyond it).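

The step in this assay is a 1.5-fold higher number from compound 2 to compound 4 (0.17 log units; within the scatter), so at this place, on a saturated chain carbon bound to an aromatic nitrogen, replacing 2,3,4-trifluorophenyl with 2,6-difluorophenyl produces no readable change. Among the compounds shown here, this is the first pair in which the fluorine count on the phenyl changes as well as the pattern, and the two changes together stay within the scatter in this ester-bearing pair. Nothing measured on these compounds offers an explanation for the result.

The pair alters fluorine count and pattern at once, which leaves their separate contributions unresolved, and any cancellation between them cannot be seen. Also open, going by these compounds, is how the number responds to a substituent other than fluorine on the phenyl, such as a chlorine or an amine.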